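From fluoro to methoxy: estimating compound 4

This account rests on a few compounds, and the source may have more. Where it says the series, first, only, none or still open, it means among the compounds named here.

- compound 1 `Fc1ccc(-c2nn(-c3ccccc3)cc2-c2nc3ccccc3[nH]2)cc1`: 3200 nM
- compound 2 `Fc1ccc(-c2nn(-c3ccccc3)cc2-c2nc3cc(F)ccc3[nH]2)cc1`: 950 nM
- compound 3 `Fc1ccc(-c2nn(-c3ccccc3)cc2-c2nc3cc(C(F)(F)F)ccc3[nH]2)cc1`: 2130 nM

In a functional assay on MCF7 cells (Homo sapiens) for antiproliferative activity, read by MTT assay, with a stated time of 48 h (a higher number here means a weaker inhibitor, a lower number a stronger inhibitor), compound 2 gives the lowest number of the three, 950 nM. Compound 4 `COc1ccc(-c2nn(-c3ccccc3)cc2-c2nc3cc(F)ccc3[nH]2)cc1` is still unmeasured. Its difference from compound 2 is methoxy in place of fluoro on an aromatic carbon.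

Among the measured compounds shown here, no measured step involves this carbon. The closest guides are changes at another place in the molecule: a 3.4-fold lower number from compound 1 to compound 2 (0.53 log units; beyond the scatter), a 2.2-fold higher number from compound 2 to compound 3 (0.35 log units; beyond the scatter) and a 1.5-fold lower number from compound 1 to compound 3 (0.18 log units; within the scatter). They suggest a modest size but fix no direction, so a slightly higher number in this assay is only a tentative expectation. The expected change is a 1.4-fold higher number from compound 2 to compound 4 (0.14 log units; within the scatter). For compound 4 the estimated value is 1300 nM, with an expected range of 400 nM to 4000 nM.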

Compound 4, half-maximal inhibitory concentration: 1510 nM
The estimate for compound 4 lay 1.2-fold (0.07 log units) below the measured number, within the range that was stated.
By their numbers in this assay, from the lowest: compounds 2, 4, 3 and 1 (each within the scatter of the next, the first and the last beyond it).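

Among the compounds shown here, at this carbon, replacing 4-fluorophenyl with 4-methoxyphenyl gives, in this assay, a 1.6-fold higher number from compound 2 to compound 4 (0.20 log units; within the scatter) and so gives the first direct reading at this position. Compound 4 carries one more heavy atom in this group and a hydrogen-bond acceptor that fluoro lacks, yet the two compounds cannot be told apart here. Nothing available explains this result.

The compounds shown leave open whether this carbon is equally forgiving of other groups, such as an amine or a carboxylic acid. They also leave open whether this tolerance would hold with a different group on the other side of the molecule.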